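The source may report more compounds than this note shows. Statements on the series, on what has been measured and on what is new or still open speak of the compounds shown alone.

Measured so far:
- compound 1, `CC(=O)Nc1cccc2c1CCCC2c1c[nH]cn1`: 35%
- compound 2, `CS(=O)(=O)Nc1cccc2c1OCCC2c1c[nH]cn1`: 17%

In a functional assay on spleen with Alpha-1B adrenergic receptor (Rattus norvegicus) as the target (a lower number here means a smaller maximal response, a higher number a larger maximal response), compound 1 gives 35%, the higher of the two numbers seen so far. Its nearest neighbour on this scale, compound 2, gives 17% in this assay, a value that lies beyond the usual scatter below compound 1. Among the measured compounds shown here, no pair of these two compounds differs in only one place, so no single structural step can be read from them.

Compound 3, `Nc1cccc2c1CCCC2c1c[nH]cn1`, has not been measured. It differs from compound 1 in one spot: hydrogen in place of acetyl on a nitrogen on an aromatic ring. Without any measured pair that isolates this kind of change, the direction cannot be inferred from the data; the expectation is a step in this assay that stays within or close to the scatter, with a slight lean downward. On that basis the expected value for compound 3 is 30% (range 10% to 55%), meaning an estimated step of a number 5 percentage points lower from compound 1 to compound 3 (within the scatter).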

Compound 3, largest response reached (reported as efficacy), in percent of the reference or control that the assay uses: 35%
The estimate for compound 3 lay 5 percentage points below the measured number; the measured number falls inside the stated range.
By their numbers in this assay, from the lowest: compound 2; then compounds 1 and 3 (each within the scatter of the next).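

Exchanging acetyl for hydrogen on the nitrogen on the aromatic ring, the change from acetamido to amino, gives no change at the digits printed from compound 1 to compound 3 (within the scatter) in this assay. Among the compounds shown here, this is the first direct look at this position: the maximal response seen with compound 1 does not require the acetyl group, and the free amino group of compound 3 serves equally well in this assay. No available measurement explains this result.

From the compounds shown here alone, whether the same holds for other groups on this nitrogen, such as a methyl or a longer propanoyl chain, remains open. Also open, going by these compounds, is what the methanesulfonyl group of compound 2 contributes, since that compound differs from compound 1 and compound 3 in more than one place.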